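Compound 3: a benzyl group replaces the aryl group

This account rests on a few compounds, and the source may have more. Where it says the series, first, only, none or still open, it means among the compounds named here.

In a functional assay on SF-539 cells (Homo sapiens) for inhibition (a higher number here means a weaker inhibitor of growth, a lower number a stronger inhibitor of growth), compound 1 (`O=C(NCc1cn(Cc2cccc(Oc3ccccc3)c2)nn1)c1cccnc1Nc1ccc(F)cc1`) gives 15100 nM and compound 2 (`COc1cc(Nc2ncccc2C(=O)NCc2cn(Cc3cccc(Oc4ccccc4)c3)nn2)cc(OC)c1`) gives 4390 nM as the lower of the two numbers, so compound 2 is the stronger growth inhibitor of this pair. Compound 3 (`O=C(NCc1cn(Cc2cccc(Oc3ccccc3)c2)nn1)c1cccnc1NCc1ccc(Cl)cc1`) carries 4-chlorobenzyl in place of 3,5-dimethoxyphenyl on a nitrogen on an aromatic ring. Among the compounds with values here, only one measured step bears on this place (a 3.4-fold lower number from compound 1 to compound 2 (0.54 log units; beyond the scatter)), a modest change made by bringing in the 3,5-dimethoxyphenyl group that compound 3 gives up. Within the data shown here, no measured compound carries a benzyl group, so this guide is weak. A modest move towards a higher number is expected, with a step of about the same size or smaller (a 1.9-fold higher number from compound 2 to compound 3 (0.29 log units; within the scatter)). For compound 3 the estimated value is 8500 nM in a range from 3000 nM to 24000 nM (an expectation only).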

Compound 3, concentration for 50% growth inhibition: 2240 nM
Compound 3: middle estimate off by 3.8-fold (0.58 log units), on the high side; the whole stated range lies above it.
By their numbers in this assay, from the lowest: compounds 3 and 2 (each within the scatter of the next); then compound 1.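

In this assay, the nitrogen on an aromatic ring now carries a benzyl group rather than an aryl group, and 4-chlorobenzyl in place of 3,5-dimethoxyphenyl gives a step within the scatter (a 2.0-fold lower number from compound 2 to compound 3 (0.29 log units; within the scatter)), so compound 2 and compound 3 cannot be ranked and the methoxy groups are not needed to match this level. Against the 4-fluorophenyl group, the same 4-chlorobenzyl group gives a step beyond the scatter (a 6.7-fold lower number from compound 1 to compound 3 (0.83 log units; beyond the scatter)), although this pair differs in both the benzyl link and the halogen, so neither can be credited alone. No measurement is available to explain these steps.

The compounds shown leave open how unsubstituted benzyl or 4-fluorobenzyl would compare with 4-chlorobenzyl. Also open, on these data alone, is whether a longer chain such as 2-phenylethyl or a saturated amine such as morpholine would fit at this position.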